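Replacing a phenyl with methyl on the shared core

The source may hold more compounds than are shown below. What is called first, only, known or untested is meant among the compounds shown, and "the series" means these compounds.

Compound 1 `Cc1c(CNC[C@@H]2CCCN3CCCC[C@H]23)cc(-c2ccccc2)n1Nc1ccnc2cc(Cl)ccc12` and compound 2 `Cc1c(CN2CCCC2)cc(-c2ccccc2)n1Nc1ccnc2cc(Cl)ccc12` share a core and were both tested in an ADME assay on WEHI13 cells (Mus musculus) for cytotoxicity, read by MTT assay; on this read-out lower numbers stand for stronger inhibition and higher numbers for weaker inhibition. In this assay compound 1 gives 7440 nM, and compound 2 gives 3880 nM. Among the measured compounds shown here, of these two numbers, compound 1 has the higher one, but its only neighbour is close: the step of a 1.9-fold lower number from compound 1 to compound 2 (0.28 log units; within the scatter) changes a chain group on a saturated carbon and stays within the scatter, so the two compounds cannot be told apart on this read-out.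

Compound 3 `Cc1cc(CNC[C@@H]2CCCN3CCCC[C@H]23)c(C)n1Nc1ccnc2cc(Cl)ccc12` differs from compound 1 at another place on the core: methyl in place of phenyl on an aromatic carbon. For the measured compounds named here, no measured pair shows this kind of change, a phenyl exchanged for a methyl on the aromatic ring, so nothing in the present numbers points to a direction. Going by the values given here, the only measured step, from compound 1 to compound 2, is within the scatter and concerns a different part of the molecule, which gives no reason to expect a shift beyond the scatter here either.

The expected step of a 1.1-fold higher number from compound 1 to compound 3 (0.03 log units; within the scatter) is therefore one of no clear change. For compound 3 the estimated value in this assay is 8000 nM, with a range from 3000 nM to 21000 nM.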

Compound 3, half-maximal inhibitory concentration: 5510 nM
Compound 3: the middle estimate sits 1.5-fold (0.16 log units) above what was measured; the measured number falls inside the stated range.
By their numbers in this assay, from the lowest: compounds 2, 3 and 1 (each within the scatter of the next).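

Exchanging the phenyl for a methyl on this aromatic carbon leaves no readable change in this assay (a 1.4-fold lower number from compound 1 to compound 3 (0.13 log units; within the scatter)). Among the compounds shown here, this is the first view of this position, which lies next to the ring nitrogen and next to the ring atom that bears a (7-chloroquinolin-4-yl)amino group, and it shows that a whole six-membered aromatic ring of carbon can give way to a single carbon while the number stays within the scatter. Nothing measured here speaks to why the number holds, so no cause can be offered for this result.

Going by these compounds, the three compounds span only a phenyl and a methyl at this position, so it stays open whether another group on this aromatic carbon, such as an amine, a carboxylic acid or a longer chain, would move the number beyond the scatter. Also open, on these data alone, is whether the exchange of phenyl for methyl would read the same on the core of compound 2, with its five-membered non-aromatic ring in place of the large group of compound 1.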